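Swapping Chloro for an Amino Ester Group on the Side Chain

A few compounds are considered here, and "the series" means these few. Any claim that something is new, unique, unknown or untested is made for them only; others in the source may bear on it.

This study concerns a small set of compounds that share one core and differ only at the end of a side chain. Compound 1 `COc1cc(-c2nc3ccccc3s2)ccc1OCC(=O)NNC(=O)CCl` carries a chloro group there; in a functional assay on HepG2 cells (Homo sapiens) for inhibition, read by MTT assay, with a stated time of 3 days (a lower number here means a stronger inhibitor, a higher number a weaker inhibitor), compound 1 gives 2890 nM. Compound 2 `COc1cc(-c2nc3ccccc3s2)ccc1OCC(=O)NNC(=O)CN[C@@H](CS)C(=O)O` replaces the chloro group with (1-carboxy-2-sulfanylethyl)amino, and in this assay compound 2 gives 3120 nM. Compound 3 `COc1cc(-c2nc3ccccc3s2)ccc1OCC(=O)NNC(=O)CN[C@@H](CCSC)C(=O)O` carries (1-carboxy-3-(methylsulfanyl)propyl)amino instead, and in this assay compound 3 gives 3780 nM. Compound 1 shows the lowest of the three numbers, yet the steps from it are small: a 1.1-fold higher number from compound 1 to compound 2 (0.03 log units; within the scatter) and a 1.3-fold higher number from compound 1 to compound 3 (0.12 log units; within the scatter), and between the two variants a 1.2-fold higher number from compound 2 to compound 3 (0.08 log units; within the scatter). Nothing here separates the three beyond the usual scatter.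

Compound 4 `CCOC(=O)[C@@H](NCC(=O)NNC(=O)COc1ccc(-c2nc3ccccc3s2)cc1OC)[C@@H](C)CC` is not yet measured. It differs from compound 1 at the same place: (1-(ethoxycarbonyl)-2-methylbutyl)amino in place of chloro on a saturated chain carbon bound to a carbonyl carbon. The two measured steps that replace chloro with an amino-bearing group both stayed within the scatter, so no step beyond the scatter is expected in this assay for compound 4 either, in neither direction. The expected number for compound 4 is therefore 3500 nM, within a range from 1700 nM to 7200 nM. That estimate means an expected 1.2-fold higher number from compound 1 to compound 4 (0.08 log units; within the scatter).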

Compound 4, half-maximal inhibitory concentration: 3460 nM
Estimate against measurement, compound 4: 1.0-fold (0.00 log units) above; measured number inside the range.
By their numbers in this assay, from the lowest: compounds 1, 2, 4 and 3 (each within the scatter of the next).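

In this assay, (1-(ethoxycarbonyl)-2-methylbutyl)amino brings an ethoxycarbonyl group where compounds 2 and 3 have a free carboxylic acid, and its side chain holds no sulfur, yet putting it in place of chloro gives a 1.2-fold higher number from compound 1 to compound 4 (0.08 log units; within the scatter). Set against the two acid-bearing side chains, the new group gives a 1.1-fold lower number from compound 3 to compound 4 (0.04 log units; within the scatter) and a 1.1-fold higher number from compound 2 to compound 4 (0.04 log units; within the scatter), so among these four compounds, this place has now taken three different amino-bearing groups and chloro with no step beyond the scatter. Nothing measured here bears on why the numbers stay so close.

Each of the steps from compound 2 and compound 3 to compound 4 swaps the whole side chain, so the part played by the ethoxycarbonyl group cannot be separated from that of the 2-methylbutyl chain; a pair differing only in ester against acid, on one and the same side chain, would be needed for that. From the compounds shown here alone, it also stays open whether a quite different group at this place, such as a plain dimethylamino group or a benzylamino group with its aromatic ring, would step beyond the scatter in this assay.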